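Swapping Benzyl for Methoxyphenoxy: an Expected Permeability Gain

The source may hold more compounds than are shown below. What is called first, only, known or untested is meant among the compounds shown, and "the series" means these compounds.

Two measured compounds share a core and a three-carbon diamine chain. Compound 1 `COc1ccc(Oc2ccc3c(NCCCNCc4cc(F)ccc4OC)ccnc3c2)cc1` is the more permeable of the pair: in an ADME assay for permeability, using PAMPA, with a stated time of 30 min, at pH 7.4 (a higher number here means that the compound crosses the layer faster, a lower number that the compound crosses the layer more slowly), compound 1 gives 317 10^-6 cm/s. Compound 2 `c1ccc(Cc2ccc3c(NCCCNCc4ccco4)ccnc3c2)cc1` stands at the lowest of the two numbers, giving 23 10^-6 cm/s in this assay, a gap to compound 1 that lies well beyond the usual scatter. Compound 3 `COc1ccc(Oc2ccc3c(NCCCNCc4ccco4)ccnc3c2)cc1` has not yet been measured. It keeps the furan of compound 2 and changes only the pendant group on the core: 4-methoxyphenoxy in place of benzyl on an aromatic carbon. Within the data shown here, no measured pair differs solely in this change, so the expectation rests on compound 1, which carries the same 4-methoxyphenoxy group and gives 317 10^-6 cm/s. The expected step is an upward one, of about a 6.5-fold higher number from compound 2 to compound 3 (0.81 log units; beyond the scatter). Compound 3 is accordingly estimated at 150 10^-6 cm/s, with a range from 50 10^-6 cm/s to 400 10^-6 cm/s.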

Compound 3, apparent permeability: 317 10^-6 cm/s
Estimate against measurement, compound 3: 2.1-fold (0.32 log units) below; the measured number falls inside the stated range.
By their numbers in this assay, from the lowest: compound 2; then compounds 1 and 3 (each within the scatter of the next).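

In this assay the change to 4-methoxyphenoxy in place of benzyl on an aromatic carbon gives a 14-fold higher number from compound 2 to compound 3 (1.14 log units; beyond the scatter) with the furan-2-yl group held fixed, so this position now has a direct reading of its own. Furan-2-yl in place of 5-fluoro-2-methoxyphenyl on the saturated chain carbon bound to the amine nitrogen gives no change at the digits printed from compound 1 to compound 3 (within the scatter) and so, with 4-methoxyphenoxy on the core, this exchange does not separate the two compounds. Nothing measured here speaks to the cause of either step.

The compounds shown leave open whether the step from benzyl carries over to a compound bearing 5-fluoro-2-methoxyphenyl. They also leave open how plain phenoxy, which would keep the oxygen link without the methoxy group, or a carboxylic acid at the same aromatic carbon would read.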